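The compounds below may be only part of what the source reports. "The series", "measured", "known", "first", "only" and "open" are said of these compounds alone.

Values in a functional assay on K562 cells (Homo sapiens), read by MTT assay, with a stated time of 72 h; a lower number here means a stronger inhibitor, a higher number a weaker inhibitor:
- compound 1 `C#Cc1cn([C@@H]2O[C@H](CO)[C@@H](O)[C@H]2O)c2ncnc(SC)c12`: 30 nM
- compound 2 `C#Cc1cn([C@@H]2O[C@H](CO)[C@@H](O)[C@H]2O)c2ncnc(NC)c12`: > 20000 nM
- compound 3 `CN(C)c1ncnc2c1c(-c1ccsc1)cn2[C@@H]1O[C@H](CO)[C@@H](O)[C@H]1O`: 530 nM
- compound 4 `C#Cc1cn([C@@H]2O[C@H](CO)[C@@H](O)[C@H]2O)c2ncnc(N(C)C)c12`: not yet measured

For the measured compounds named here, of the two values that are numbers, compound 3 has the higher, at 530 nM, and its only numerical neighbour is compound 1 at 30 nM. Compound 2 gives > 20000 nM, which is a limit of the assay.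

The change to compound 4 is ethynyl in place of thiophen-3-yl on an aromatic carbon. The dimethylamino group of compound 3 stays. Going by the values given here, no measured step covers this exchange directly. Among the compounds with values here, the one measured step, an at least 660-fold higher number from compound 1 to compound 2 (2.82 log units; beyond the scatter), lies at the other substituted place, with ethynyl kept, and it is large and beyond the scatter. Ethynyl therefore goes with both a low number and a limit, depending on the neighbouring group. Compound 4 carries dimethylamino where compound 2 carries methylamino, so it is read as closer to compound 2 than to compound 1. A move to a higher number in this assay is therefore expected, of moderate to large size, though with wide uncertainty. The expected step is a 7.5-fold higher number from compound 3 to compound 4 (0.88 log units; beyond the scatter). For compound 4 the estimate is 4000 nM, with an expected range of 400 nM to 20000 nM.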

Compound 4, half-maximal inhibitory concentration: 110 nM
The estimate for compound 4 lay 36-fold (1.56 log units) above the measured number; the measured number lies below the stated range.
By their numbers in this assay, from the lowest: compound 1; then compound 4; then compound 3. At a limit, above all of these: compound 2.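

In this assay, for the compounds shown here, with dimethylamino kept, the exchange on the aromatic carbon of the five-membered ring gives a 4.8-fold lower number from compound 3 to compound 4 (0.68 log units; beyond the scatter), the first reading at this position, and it favours ethynyl over thiophen-3-yl. At the other substituted place, with ethynyl kept, methyl in place of hydrogen on the nitrogen gives an at least 180-fold lower number from compound 2 to compound 4 (2.25 log units; beyond the scatter), a large step counted from the value of compound 2, which is a limit and not a number: the limit of > 20000 nM in this assay, at which 1 of the 4 values shown sits. Dimethylamino in place of methylsulfanyl gives only a 3.7-fold higher number from compound 1 to compound 4 (0.56 log units; beyond the scatter), against an at least 660-fold higher number from compound 1 to compound 2 (2.82 log units; beyond the scatter) for methylamino, so the large rise seen with methylamino does not carry over to dimethylamino.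

Going by these compounds, the position rests on a single pair, so it remains open whether ethynyl keeps its edge over thiophen-3-yl when methylsulfanyl or methylamino stands at the other substituted place. Also open, on these data alone, is how a nitrile, a bromine atom or a longer alkyne chain would read on the same carbon, and how an unsubstituted amine or a methoxy group would read at the other substituted place.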